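Ethoxycarbonyl to benzyloxycarbonyl on the shared core

The compounds below may be only part of what the source reports. "The series", "measured", "known", "first", "only" and "open" are said of these compounds alone.

In a functional assay on A2780 cells (Homo sapiens) for antiproliferative activity, read by MTT assay, with a stated time of 48 h (a higher number here means a weaker inhibitor of growth, a lower number a stronger inhibitor of growth), compound 1 (`COc1cc(C2CC(c3ccccc3)=NN2C(=O)OCc2ccccc2)cc(OC)c1OC`) gives > 10000 nM as a limit of the assay, not a number. Among the measured compounds shown here, compound 2 (`CCOC(=O)N1N=C(c2cccc(OC)c2)CC1c1cc(OC)c(OC)c(OC)c1`) gives 7300 nM there, the only actual number so far, so its standing cannot yet be judged against a second number. Compound 3 (`COc1cccc(C2=NN(C(=O)OCc3ccccc3)C(c3cc(OC)c(OC)c(OC)c3)C2)c1`) differs from compound 2 by phenyl in place of methyl on a saturated chain carbon bound to an oxygen next to a carbonyl group, so that ethoxycarbonyl becomes benzyloxycarbonyl (phenyl in place of methyl on a saturated chain carbon bound to an oxygen next to a carbonyl group). For the measured compounds named here, no measured step isolates this change. Compound 1 also carries benzyloxycarbonyl, and its > 10000 nM is again only a limit. On that slim basis the expected 1.2-fold higher number from compound 2 to compound 3 (0.09 log units; within the scatter) is small, toward weaker growth inhibition, and possibly within the scatter. Compound 3 is estimated at 9000 nM in this assay (expected range 3500 nM to 20000 nM).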

Compound 3, concentration for 50% growth inhibition: > 10000 nM
Compound 3 was reported as a limit; the forecaster's own chance of this, stated with the estimate: 45%; at least 1.1-fold (0.04 log units) between middle value and limit.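

In this assay, ethoxycarbonyl to benzyloxycarbonyl on the shared core gives an at least 1.3-fold higher number from compound 2 to compound 3 (0.13 log units; that floor lies within the scatter). Among the compounds shown here, this is the only readable step at this position, and it has a direction but only a floor: phenyl in place of methyl on a saturated chain carbon bound to an oxygen next to a carbonyl group shows no gain in growth inhibition, and the true size of the step stays unknown. The step that links the two benzyloxycarbonyl compounds, compound 1 and compound 3, cannot be read, since both ends are limits: the limit of > 10000 nM in this assay, at which 2 of the 3 values shown sit.

Going by these compounds, how far the number for compound 3 lies past the limit remains open. Also open, on these data alone, is how a longer chain such as propyl, or an amine or a carboxylic acid on that chain, would read in this assay.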